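A Methoxy Group Takes the Place of Fluoro in Compound 4

The source may report more compounds than this note shows. Statements on the series, on what has been measured and on what is new or still open speak of the compounds shown alone.

In a functional assay on HUVEC cells (Homo sapiens) for inhibition, with a stated time of 4 days (on this read-out higher numbers stand for weaker inhibition and lower numbers for stronger inhibition), three compounds have been measured so far. Compound 1 (`CCc1ccc(OC)c(COc2ccc(Cl)c(C)c2)c1`) gives 40000 nM. Compound 2 (`COc1ccc(C(N)=O)cc1/C=C/c1ccccc1`) gives 2400 nM, and compound 3 (`COc1ccc(C(N)=O)cc1/C=C/c1ccccc1F`) gives 2000 nM. Compound 3 therefore stands level with compound 2 within the scatter, and the numbers of both lie far under that of compound 1.

The next compound is compound 4 (`COc1ccccc1/C=C/c1cc(C(N)=O)ccc1OC`), which carries methoxy in place of fluoro on an aromatic carbon, ortho to a large group: methoxy in place of fluoro on an aromatic carbon.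

Among the measured compounds shown here, one measured step bears on this change, the fluoro in place of hydrogen on that same aromatic carbon. It gave a 1.2-fold lower number from compound 2 to compound 3 (0.08 log units; within the scatter). For the measured compounds named here, no measured compound has methoxy at this carbon, and a single small step is thin evidence, so the range of the estimate is kept wide. On that basis, no step beyond the scatter is expected in this assay. The estimated step is a 1.3-fold higher number from compound 3 to compound 4 (0.10 log units; within the scatter). For compound 4 the expected value is 2500 nM, with an estimated range from 900 nM to 7000 nM.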

Compound 4, half-maximal inhibitory concentration: 5700 nM
Estimate against measurement, compound 4: 2.3-fold (0.36 log units) below; low and high end bracket the measured number.
By their numbers in this assay, from the lowest: compounds 3 and 2 (each within the scatter of the next); then compound 4; then compound 1.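

In this assay the aromatic carbon ortho to a large group now shows a step beyond the scatter, with methoxy in place of fluoro giving a 2.9-fold higher number from compound 3 to compound 4 (0.45 log units; beyond the scatter) and methoxy in place of hydrogen giving a 2.4-fold higher number from compound 2 to compound 4 (0.38 log units; beyond the scatter) on the same carbon. Among the compounds shown here, the only earlier step at this carbon, fluoro in place of hydrogen, gave a 1.2-fold lower number from compound 2 to compound 3 (0.08 log units; within the scatter) and so left open whether the carbon responds to any change at all; among hydrogen, fluoro and methoxy, only methoxy now moves the number beyond the scatter, and both of its steps are modest. Nothing measured here accounts for this rise in the number.

From the compounds shown here alone, what an ethoxy, a hydroxyl or an amine would give at this carbon stays open, so it cannot yet be said whether the rise belongs to methoxy alone or would also appear with other groups. The compounds shown also leave open whether methoxy would bring a similar step at another carbon of this ring.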